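Morpholine Amide Replaces Methoxyethyl Amide on Quinazoline Piperidine

The source may hold more compounds than are shown below. What is called first, only, known or untested is meant among the compounds shown, and "the series" means these compounds.

Measured compounds:
- compound 1 `CCNC(=O)C1CCN(c2nc(N)c3cc(OC)c(OC)cc3n2)CC1`: 1.64 nM
- compound 2 `CCCCNC(=O)C1CCN(c2nc(N)c3cc(OC)c(OC)cc3n2)CC1`: 0.67 nM
- compound 3 `COCCNC(=O)C1CCN(c2nc(N)c3cc(OC)c(OC)cc3n2)CC1`: 1.13 nM

In an assay on isolated protein for displacement of a labelled ligand from Adrenergic receptor alpha-1 (Rattus norvegicus) (on this read-out lower numbers stand for stronger inhibition and higher numbers for weaker inhibition), compound 3 sits second of the three numbers. Its nearest neighbour is compound 1, and the two lie within the scatter of each other, as a 1.5-fold lower number from compound 1 to compound 3 (0.16 log units; within the scatter) shows; the gap to compound 2, a 1.7-fold higher number from compound 2 to compound 3 (0.23 log units; within the scatter), is also within the scatter. Only a 2.4-fold lower number from compound 1 to compound 2 (0.39 log units; beyond the scatter) stands beyond it.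

Compound 4 `COc1cc2nc(N3CCC(C(=O)N4CCOCC4)CC3)nc(N)c2cc1OC` differs from compound 3 in one place: morpholin-4-yl in place of (2-methoxyethyl)amino on a carbonyl carbon. The amide carbon and the piperidine are unchanged; what changes is the group on the amide nitrogen, which becomes part of a ring and loses its hydrogen-bond donor.

Going by the values given here, none of the measured steps alters the amide nitrogen in the same way; all three vary only the chain that hangs from it. They show that the chain beyond the amide nitrogen can be altered with little effect in this assay, the largest move being a 2.4-fold lower number from compound 1 to compound 2 (0.39 log units; beyond the scatter). Closing the chain into a morpholine ring is a different kind of change, so the expectation carries extra uncertainty. The step from compound 3 to compound 4 is therefore expected to be small, a 1.3-fold higher number from compound 3 to compound 4 (0.12 log units; within the scatter), in either direction. Compound 4 is estimated at 1.5 nM, with a range from 0.5 nM to 5 nM.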

Compound 4, inhibition constant: 1.14 nM
For compound 4 the middle estimate is 1.3-fold (0.12 log units) above the measured one; the range from low to high includes it.
By their numbers in this assay, from the lowest: compounds 2, 3, 4 and 1 (each within the scatter of the next, the first and the last beyond it).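

In this assay, going by these compounds alone, the earlier compounds varied only the chain on the amide nitrogen, whereas the morpholin-4-yl group of compound 4 closes that chain into a six-membered ring and carries no hydrogen-bond donor; a 1.0-fold higher number from compound 3 to compound 4 (0.00 log units; within the scatter) shows that this position accepts the swap from (2-methoxyethyl)amino. The comparisons with the other two open-chain amides agree, with a 1.7-fold higher number from compound 2 to compound 4 (0.23 log units; within the scatter) for butylamino and a 1.4-fold lower number from compound 1 to compound 4 (0.16 log units; within the scatter) for ethylamino, so among these four compounds neither the amide hydrogen nor an open chain is needed to keep the number within the scatter of those amides. No evidence is available to explain this tolerance.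

The compounds shown leave open whether another ring on the same carbonyl carbon, such as piperidin-1-yl without the ring oxygen or 4-methylpiperazin-1-yl with a second ring nitrogen, would also stay within the scatter of compound 4. They also leave open whether the carbonyl itself is needed, as an aminomethyl group in place of the whole carbamoyl unit would test.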